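The source may report more compounds than this note shows. Statements on the series, on what has been measured and on what is new or still open speak of the compounds shown alone.

Measured so far in a functional assay on MDA-MB-231 cells (Homo sapiens) for antiproliferative activity, read by MTT assay, with a stated time of 48 h; a higher number here means a weaker inhibitor, a lower number a stronger inhibitor:
- compound 1 `Cc1c(Cc2ccccc2)c(=O)oc2cc(OCCOc3no[n+]([O-])c3S(=O)(=O)c3ccccc3)ccc12`: 6 nM
- compound 2 `Cc1c(Cc2ccc(F)cc2)c(=O)oc2cc(OCCOc3no[n+]([O-])c3S(=O)(=O)c3ccccc3)ccc12`: 0.8 nM
- compound 3 `CNS(=O)(=O)Nc1cccc(Cc2c(C)c3ccc(OCCOc4no[n+]([O-])c4S(=O)(=O)c4ccccc4)cc3oc2=O)c1`: not yet measured

Of the two measured compounds, compound 2 holds the lower number, at 0.8 nM. Going on to compound 3, the change is 3-((methylsulfamoyl)amino)phenyl in place of 4-fluorophenyl on a saturated chain carbon bound to an aromatic carbon.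

Among the measured compounds shown here, only one measured step bears on this: a 7.5-fold lower number from compound 1 to compound 2 (0.88 log units; beyond the scatter). It concerns the fluoro of the group that leaves. For the measured compounds named here, no measured compound carries the entering group, so the guidance is thin. Compound 1, which lacks the fluoro, reads 6 nM, so a step of similar size towards a higher number is expected in this assay. The expected change is a 6.3-fold higher number from compound 2 to compound 3 (0.80 log units; beyond the scatter). For compound 3 the estimated value is 5 nM, with an expected range of 0.8 nM to 30 nM.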

Compound 3, half-maximal inhibitory concentration: 1.1 nM
For compound 3 the middle estimate is 4.5-fold (0.66 log units) above the measured one; low and high end bracket the measured number.
By their numbers in this assay, from the lowest: compounds 2 and 3 (each within the scatter of the next); then compound 1.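

In this assay, the saturated chain carbon bound to an aromatic carbon accepts 3-((methylsulfamoyl)amino)phenyl in place of 4-fluorophenyl, a much larger group carrying hydrogen-bond donors and acceptors, with a 1.4-fold higher number from compound 2 to compound 3 (0.14 log units; within the scatter). Adding the (methylsulfamoyl)amino group to the unsubstituted ring, the series shows a 5.5-fold lower number from compound 1 to compound 3 (0.74 log units; beyond the scatter), so among these three compounds the lower number is not confined to the fluoro: both substituted rings read lower than the unsubstituted one. No measurement at hand explains either step.

The compounds shown do not separate the identity of a ring substituent from its place, as the two names carry theirs at different ring positions. From the compounds shown here alone, it also remains open whether a simple amine or a carboxylic acid on the same ring would serve as well as the methylsulfamoyl unit.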